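The source may hold more compounds than are shown below. What is called first, only, known or untested is meant among the compounds shown, and "the series" means these compounds.

Working notes on the series.

Compound 1 `C[C@@H](C(=O)O)c1nn(Cc2cn3cc(OCC4CC4)c(Cl)cc3n2)c2ccccc2c1=O` in a functional assay on CHO cells for antagonist activity at sphingosine 1-phosphate receptor 2 (Homo sapiens), read by GTPgammaS binding (a higher number here means a weaker inhibitor, a lower number a stronger inhibitor), gives 253 nM. Compound 2 `O=C(O)Cc1nn(Cc2cn3cc(OCC4CC4)c(Cl)cc3n2)c2ccccc2c1=O`, with hydrogen in place of methyl on the saturated chain carbon, gives 30 nM in this assay, a step of an 8.4-fold lower number from compound 1 to compound 2 (0.93 log units; beyond the scatter). Compound 3 `C[C@H](C(=O)O)c1nn(Cc2cn3cc(OCC4CC4)c(Cl)cc3n2)c2ccccc2c1=O` gives 16 nM in this assay and stands lowest of the three numbers, with compound 2 nearest and within the scatter, and compound 1 furthest. The step of a 16-fold lower number from compound 1 to compound 3 (1.20 log units; beyond the scatter) is the largest in the set and rests on (the fact that compounds 1 and 3 differ only in the configuration as drawn), so the configuration of that chain carbon carries most of the spread seen so far; the step of a 1.9-fold lower number from compound 2 to compound 3 (0.27 log units; within the scatter) adds little beyond it.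

Compound 4 `COC(C(=O)O)c1nn(Cc2cn3cc(OCC4CC4)c(Cl)cc3n2)c2ccccc2c1=O` has not yet been run in this assay. Relative to compound 3 the change is carboxy(methoxy)methyl in place of 1-carboxyethyl on an aromatic carbon. Going by the values given here, the entering group carries no defined stereocentre, so compound 4 is read as a mixture at the chain carbon, and the steps that bear on it are a 16-fold lower number from compound 1 to compound 3 (1.20 log units; beyond the scatter) and a 1.9-fold lower number from compound 2 to compound 3 (0.27 log units; within the scatter): the configuration matters greatly, the methyl itself hardly at all. A mixture would be expected to land between compound 1 and compound 3, with the methoxy an added unknown, giving an expected step of a 3.1-fold higher number from compound 3 to compound 4 (0.49 log units; beyond the scatter). Compound 4 is thus estimated at 50 nM, with a range of 12 nM to 250 nM.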

Compound 4, half-maximal inhibitory concentration: 58 nM
The estimate for compound 4 lay 1.2-fold (0.06 log units) below the measured number, within the range that was stated.
By their numbers in this assay, from the lowest: compounds 3, 2 and 4 (each within the scatter of the next, the first and the last beyond it); then compound 1.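

The chain carbon accepts a methoxy as well as a methyl in this assay: with methoxy in place of hydrogen the step is a 1.9-fold higher number from compound 2 to compound 4 (0.29 log units; within the scatter), so this oxygen-linked group leaves the number where compound 2 stands. Set against the two single configurations of the methyl pair, carboxy(methoxy)methyl lies apart from both, with a 3.6-fold higher number from compound 3 to compound 4 (0.56 log units; beyond the scatter) on one side and a 4.4-fold lower number from compound 1 to compound 4 (0.64 log units; beyond the scatter) on the other, so the large loss seen with compound 1 is not reproduced by compound 4. Going by these compounds alone, compound 4 has no defined stereocentre at the chain carbon, so its number cannot be divided between the methoxy and the configuration, and the only direct reading of configuration remains the methyl pair: the fact that compounds 1 and 3 differ only in the configuration as drawn.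

As far as these compounds go, what stays open is how each single configuration of the methoxy compound would stand, and whether the same configuration is favoured with methoxy as with methyl. Also open, from the compounds shown here alone, is whether the chain carbon would accept other groups, such as a hydroxy, a fluorine or an ethyl, and whether an amide could take the place of the carboxylic acid.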